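This account rests on a few compounds, and the source may have more. Where it says the series, first, only, none or still open, it means among the compounds named here.

Compound 1 `O=c1cc(NC2CC2)cc(-c2ccccc2)o1` in a functional assay on DU-145 cells (Homo sapiens) for cytotoxicity, read by MTT assay, with a stated time of 72 h (a lower number here means that less compound is needed, a higher number that more compound is needed for the effect), gives > 30 uM, which is a limit of the assay.
Compound 2 `O=c1cc(Nc2ccccc2)cc(-c2ccccc2)o1` in this assay gives 0.098 uM.
Compound 3 `COc1ccc(Nc2cc(-c3ccccc3)oc(=O)c2)cc1` in this assay gives 0.12 uM.

Among the two numbers shown, compound 3 holds the higher one. Its nearest neighbour is compound 2, and a 1.2-fold higher number from compound 2 to compound 3 (0.09 log units; within the scatter) lies within the usual scatter, so the two cannot be ordered. Compound 1 sits at a limit of > 30 uM in this assay, at which 1 of the 3 values shown sits, and contributes no number.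

Compound 4 `O=c1cc(Nc2ccc(Br)cc2)cc(-c2ccccc2)o1` is not yet measured. It differs from compound 3 in one place: bromo in place of methoxy on an aromatic carbon. Of the measured steps, a 1.2-fold higher number from compound 2 to compound 3 (0.09 log units; within the scatter) bears on it most directly, since it changes the group on the same aromatic carbon and moved the number by no more than the scatter. The other step, an at least 300-fold lower number from compound 1 to compound 2 (2.48 log units; beyond the scatter), concerns the group on the nitrogen rather than a substituent on that ring, and so says little about this change. On this basis no step beyond the scatter is expected for compound 4 in this assay, in either direction. Compound 4 is therefore expected to give about 0.12 uM, with a range from 0.05 uM to 0.3 uM. The expected step is no change at the digits printed from compound 3 to compound 4 (within the scatter), a change inside the scatter.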

Compound 4, concentration for half-maximal effect: 0.34 uM
The estimate for compound 4 lay 2.8-fold (0.45 log units) below the measured number, outside the stated range (above it).
By their numbers in this assay, from the lowest: compounds 2 and 3 (each within the scatter of the next); then compound 4. At a limit, above all of these: compound 1.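

Compound 4 shows that the group on an aromatic carbon para to a large group can matter in this assay: methoxy had left the number within the scatter of hydrogen, but bromo gives a 3.5-fold higher number from compound 2 to compound 4 (0.54 log units; beyond the scatter) and a 2.8-fold higher number from compound 3 to compound 4 (0.45 log units; beyond the scatter), so this place is not indifferent to every replacement. The change of group on the nitrogen still has the larger effect, with 4-bromophenyl in place of cyclopropyl giving an at least 88-fold lower number from compound 1 to compound 4 (1.94 log units; beyond the scatter), so the bromo-bearing aryl group retains a large advantage over the cyclopropyl group. That last step has only one fixed end, since the value of compound 1 is a limit and not a number: the limit of > 30 uM in this assay, at which 1 of the 4 values shown sits.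

The compounds shown test this place only with hydrogen, methoxy and bromo, so it remains open whether chloro, methyl or an amine would stay level with the first two or follow bromo. On these data alone, it also remains open whether the difference between bromo and methoxy would hold on a different core or in a different cell line.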